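Swapping the amide aryl group: clearance of compound 4

The source may report more compounds than this note shows. Statements on the series, on what has been measured and on what is new or still open speak of the compounds shown alone.

Measured compounds and their values:
Compound 1, `Cc1ccc(NC(=O)[C@H]2CN(C)C[C@@H]2c2ccc(/C=C/C(=O)Nc3ccccc3N)cc2)cc1`, gives 15 mL/min/kg in an in vitro ADME assay on microsomes from liver (Homo sapiens) for pharmacokinetics, read by LC-MS, with a stated time of 10 min, tested at 1 uM; a higher number here means faster removal of the compound, a lower number slower removal.
Compound 2, `CN1C[C@H](C(=O)Nc2ccc(C(F)(F)F)cc2)[C@@H](c2ccc(/C=C/C(=O)Nc3ccccc3N)cc2)C1`, gives 6 mL/min/kg in this assay.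
Compound 3, `CN1C[C@H](C(=O)Nc2ccc(Cl)c(Cl)c2)[C@@H](c2ccc(/C=C/C(=O)Nc3ccccc3N)cc2)C1`, gives 14 mL/min/kg in this assay.

Compound 2 stands lowest of the three in this assay, with compound 3 nearest and compound 1 furthest, both beyond the scatter. The unmeasured compound 4, `CN1C[C@H](C(=O)Nc2ccc(Cl)cn2)[C@@H](c2ccc(/C=C/C(=O)Nc3ccccc3N)cc2)C1`, differs from compound 2 in one place: 5-chloropyridin-2-yl in place of 4-(trifluoromethyl)phenyl on an amide-type nitrogen. A six-membered aromatic ring of carbon only gives way to a six-membered aromatic ring with 1 hetero atom, which brings 1 hydrogen-bond acceptor.

Among the compounds with values here, two measured steps bear on this kind of change at the same amide-type nitrogen. From compound 1 to compound 2 the number fell, a 2.5-fold lower number from compound 1 to compound 2 (0.40 log units; beyond the scatter), and from compound 2 to compound 3 it rose again, a 2.3-fold higher number from compound 2 to compound 3 (0.37 log units; beyond the scatter). Compound 2 is thus the low point, and the other groups tried on this nitrogen both gave higher numbers. Compound 4 is therefore expected to move back up modestly, a 1.8-fold higher number from compound 2 to compound 4 (0.26 log units; within the scatter), though the change may also stay within the scatter. The estimate for compound 4 is 11 mL/min/kg, ranging from 5 mL/min/kg to 22 mL/min/kg.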

Compound 4, clearance: 13 mL/min/kg
Compound 4: the middle estimate sits 1.2-fold (0.07 log units) below what was measured; measured number inside the range.
By their numbers in this assay, from the lowest: compound 2; then compounds 4, 3 and 1 (each within the scatter of the next).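

In this assay, the 5-chloropyridin-2-yl group does not hold the low number seen with 4-(trifluoromethyl)phenyl on this amide-type nitrogen: the result is a 2.2-fold higher number from compound 2 to compound 4 (0.34 log units; beyond the scatter), a modest move. Compound 4 instead joins the other two aryl amides, with a 1.1-fold lower number from compound 3 to compound 4 (0.03 log units; within the scatter) and a 1.2-fold lower number from compound 1 to compound 4 (0.06 log units; within the scatter), so a ring with a hetero atom and rings of carbon only can give matching numbers here, while compound 2 alone stands apart. The data shown offer no measurement that explains this separation.

Compound 4 differs from compound 2 in both the ring and its substituent, so the step cannot say which of the two changes matters. A 5-(trifluoromethyl)pyridin-2-yl group or a 4-chlorophenyl group on the same nitrogen would pull these two changes apart, and a nitrile on the ring remains an open option as well.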